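The source may report more compounds than this note shows. Statements on the series, on what has been measured and on what is new or still open speak of the compounds shown alone.

Compound 1 `N#Cc1ccc(-n2cc(COc3cccc(NC(=O)Nc4ccc(Cl)c(C(F)(F)F)c4)c3)nn2)cc1` gives 2980 nM in a functional assay on HepG2 cells (Homo sapiens) for inhibition, read by MTT assay, with a stated time of 72 h; a lower number here means a stronger inhibitor, a higher number a weaker inhibitor. Compound 2 `O=C(Nc1cccc(OCc2cn(-c3ccc(F)cc3)nn2)c1)Nc1ccc(Cl)c(C(F)(F)F)c1` gives 1350 nM in this assay; from compound 1 to compound 2 the change gave a 2.2-fold lower number from compound 1 to compound 2 (0.34 log units; beyond the scatter). Among the compounds with values here, compound 2 thus holds the lower of the two numbers measured so far. Compound 3 `O=C(Nc1cccc(OCc2cn(-c3ccccc3Cl)nn2)c1)Nc1ccc(Cl)c(C(F)(F)F)c1` carries 2-chlorophenyl in place of 4-fluorophenyl on an aromatic nitrogen. Within the data shown here, the only measured step that bears on this position is a 2.2-fold lower number from compound 1 to compound 2 (0.34 log units; beyond the scatter), a modest one, and no step between two different halogen-bearing phenyl groups here has been measured. Compound 3 is therefore expected to give a 1.1-fold higher number from compound 2 to compound 3 (0.05 log units; within the scatter), a step not beyond the scatter. The estimate for compound 3 is 1500 nM, with a range of 600 nM to 4000 nM.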

Compound 3, half-maximal inhibitory concentration: 1960 nM
For compound 3 the middle estimate is 1.3-fold (0.12 log units) below the measured one; low and high end bracket the measured number.
By their numbers in this assay, from the lowest: compounds 2, 3 and 1 (each within the scatter of the next, the first and the last beyond it).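

In this assay, 2-chlorophenyl on the aromatic nitrogen cannot be separated from either earlier aryl group (a 1.5-fold higher number from compound 2 to compound 3 (0.16 log units; within the scatter)) (a 1.5-fold lower number from compound 1 to compound 3 (0.18 log units; within the scatter)). The change from 4-fluorophenyl swaps the halogen and shifts its ring place in one step, so neither effect can be read alone. No available measurement accounts for this result. 4-Chlorophenyl or 2-fluorophenyl would pull those two changes apart. On these data alone, whether an amine or a carboxylic acid on this phenyl, or cyclohexyl in its place, moves the number beyond the scatter remains open.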